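The compounds below may be only part of what the source reports. "The series", "measured", "known", "first", "only" and "open" are said of these compounds alone.

Working notes on the series.

Three members of the series share one core and differ only in the amine at the end of the chain on the aromatic oxygen. Compound 1 `COc1cc2c(Oc3ccc(NC(=O)c4nn(-c5ccccc5OC(F)(F)F)c(=O)cc4C)cc3F)ccnc2cc1OCCCN1CCCC1` carries a pyrrolidin-1-yl group; in a functional assay on NCI-H460 cells (Homo sapiens) for inhibition, read by MTT assay, with a stated time of 72 h (on this read-out lower numbers stand for stronger inhibition and higher numbers for weaker inhibition), compound 1 gives 210 nM. Compound 2 `COc1cc2c(Oc3ccc(NC(=O)c4nn(-c5ccccc5OC(F)(F)F)c(=O)cc4C)cc3F)ccnc2cc1OCCCN1CCC(C)CC1` carries 4-methylpiperidin-1-yl in its place, and in this assay compound 2 gives 290 nM. Compound 3 `COc1cc2c(Oc3ccc(NC(=O)c4nn(-c5ccccc5OC(F)(F)F)c(=O)cc4C)cc3F)ccnc2cc1OCCCN1CCN(C)CC1` carries 4-methylpiperazin-1-yl, and in this assay compound 3 gives 260 nM. The steps among them are a 1.4-fold higher number from compound 1 to compound 2 (0.14 log units; within the scatter), a 1.2-fold higher number from compound 1 to compound 3 (0.09 log units; within the scatter) and a 1.1-fold lower number from compound 2 to compound 3 (0.05 log units; within the scatter); on the numbers shown compound 2 is the one with the highest value, yet every step to it stays inside the scatter, so the three amines cannot be told apart here.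

Compound 4 `COc1cc2c(Oc3ccc(NC(=O)c4nn(-c5ccc(Cl)cc5)c(=O)cc4C)cc3F)ccnc2cc1OCCCN1CCC(C)CC1` is the next member, to be measured in this assay. It keeps the 4-methylpiperidin-1-yl chain of compound 2 and changes the other end: 4-chlorophenyl in place of 2-(trifluoromethoxy)phenyl on an aromatic nitrogen. For the measured compounds named here, none of the measured steps touches this position; all three sit at the amine, so nothing measured bears on the change from compound 2 to compound 4. Without a guide at this site, the expectation is a step near zero, a 1.1-fold higher number from compound 2 to compound 4 (0.04 log units; within the scatter), with a wide range. Compound 4 is thus estimated at 320 nM, between 100 nM and 1000 nM.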

Compound 4, half-maximal inhibitory concentration: 370 nM
Estimate against measurement, compound 4: 1.2-fold (0.06 log units) below; measured number inside the range.
By their numbers in this assay, from the lowest: compounds 1, 3, 2 and 4 (each within the scatter of the next).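

For the compounds shown here, the first step at the aromatic nitrogen, 4-chlorophenyl in place of 2-(trifluoromethoxy)phenyl, comes to a 1.3-fold higher number from compound 2 to compound 4 (0.11 log units; within the scatter) in this assay, so within this pair the two aryl groups cannot be told apart on this read-out. The group that leaves has 11 heavy atoms and 1 hydrogen-bond acceptor, while the group that enters has 7 heavy atoms and no hydrogen-bond acceptor, so this difference in make-up comes with no readable difference in the number. No supporting data accompany this pair that could account for the result.

As far as these compounds go, this position rests on a single pair, so it remains open whether a plain phenyl, a 4-methoxyphenyl, a pyridin-2-yl or a saturated cyclohexyl on the same nitrogen would also stay within the scatter of compound 2. Going by these compounds alone, the 4-chlorophenyl group is also seen only with the 4-methylpiperidin-1-yl chain, which leaves open how it behaves alongside the pyrrolidin-1-yl or 4-methylpiperazin-1-yl chains of compound 1 and compound 3.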